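Swapping the Pyrrolidine Tail for a Piperidine Tail

The compounds below may be only part of what the source reports. "The series", "measured", "known", "first", "only" and "open" are said of these compounds alone.

Of the compounds shown here, three built on one shared core have been measured in a functional assay on NCI-H460 cells (Homo sapiens) for inhibition, read by MTT assay, with a stated time of 72 h; on this read-out lower numbers stand for stronger inhibition and higher numbers for weaker inhibition. Compound 1 `COc1ccc(-n2nc(C(=O)Nc3ccc(Oc4ccnc5cc(OCCCN6CCCC6)c(OC)cc45)c(F)c3)c(C)cc2=O)cc1` gives 3610 nM in this assay, and compound 2 `COc1ccc(-n2nc(C(=O)Nc3ccc(Oc4ccnc5cc(OCCCN6CCCCC6)c(OC)cc45)c(F)c3)c(C)cc2=O)cc1` gives 3730 nM. The change between them is piperidin-1-yl in place of pyrrolidin-1-yl on a saturated chain carbon, three bonds along the chain from an oxygen on an aromatic ring, and it made a step of a 1.0-fold higher number from compound 1 to compound 2 (0.01 log units; within the scatter). Compound 3 `COc1cc2c(Oc3ccc(NC(=O)c4nn(-c5ccc(Cl)cc5)c(=O)cc4C)cc3F)ccnc2cc1OCCCN1CCCC1` differs from compound 1 by chloro in place of methoxy on an aromatic carbon, and that change made a step of a 10-fold lower number from compound 1 to compound 3 (1.00 log units; beyond the scatter), leaving compound 3 at 360 nM in this assay.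

Compound 4 `COc1cc2c(Oc3ccc(NC(=O)c4nn(-c5ccc(Cl)cc5)c(=O)cc4C)cc3F)ccnc2cc1OCCCN1CCCCC1` has not yet been measured. It differs from compound 3 by piperidin-1-yl in place of pyrrolidin-1-yl on a saturated chain carbon, three bonds along the chain from an oxygen on an aromatic ring, the same change that was made from compound 1 to compound 2, at the same place. The cores of the two pairs differ by chloro in place of methoxy on an aromatic carbon. Since the earlier step of a 1.0-fold higher number from compound 1 to compound 2 (0.01 log units; within the scatter) stayed within the scatter, the expected step from compound 3 to compound 4 is also small, about a 1.0-fold higher number from compound 3 to compound 4 (0.01 log units; within the scatter), resting on a single example. On that basis the expected value for compound 4 in this assay is 370 nM, with a likely range from 180 nM to 750 nM.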

Compound 4, half-maximal inhibitory concentration: 460 nM
Compound 4: middle estimate off by 1.2-fold (0.09 log units), on the low side; the range from low to high includes it.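

In this assay, piperidin-1-yl in place of pyrrolidin-1-yl on the chloro core gave a 1.3-fold higher number from compound 3 to compound 4 (0.11 log units; within the scatter) and so stayed as small as on the methoxy core: the same change on two cores in this assay, a 1.0-fold higher number (0.01 log units; within the scatter) from compound 1 to compound 2 and a 1.3-fold higher number (0.11 log units; within the scatter) from compound 3 to compound 4, 1.2-fold (0.09 log units) apart, within the scatter of two such steps.

Chloro in place of methoxy, read with the piperidine tail in place, gave an 8.1-fold lower number from compound 2 to compound 4 (0.91 log units; beyond the scatter) and so kept nearly the size it had with the pyrrolidine tail: the same change on two cores in this assay, a 10-fold lower number (1.00 log units; beyond the scatter) from compound 1 to compound 3 and an 8.1-fold lower number (0.91 log units; beyond the scatter) from compound 2 to compound 4, 1.2-fold (0.09 log units) apart, within the scatter of two such steps.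

Across these four compounds, the two changes therefore behave as separate steps, with the choice of tail making little difference and the chloro group accounting for the large gap, but two pairs on two cores in one cell assay cannot show why or establish a rule for other cores.

Still open, from the compounds shown here alone, is whether a tail with a different amine, such as morpholine or dimethylamine, or a longer chain would also leave the number within the scatter. Going by these compounds, it is also open whether fluoro or trifluoromethyl in place of the chloro would give a step of similar size.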